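Two dienone analogues measured, a third one awaited

This account rests on a few compounds, and the source may have more. Where it says the series, first, only, none or still open, it means among the compounds named here.

Measured so far:
- compound 1, `COc1cc(/C=C2\CCC/C(=C\c3cccc(OC)c3OC)C2=O)cc(OC)c1`: 13100 nM
- compound 2, `COc1ccc(/C=C2\CCC/C(=C\c3ccccc3Br)C2=O)cc1OC`: 21800 nM

Both compounds were tested in an ADME assay on NHDF cells (Homo sapiens) for cytotoxicity, read by MTT assay, with a stated time of 72 h; on this read-out lower numbers stand for stronger inhibition and higher numbers for weaker inhibition. In this assay compound 1 gives 13100 nM and compound 2 gives 21800 nM. Of the two numbers, compound 2 stands at the highest, yet the gap to compound 1 lies within the usual scatter of the assay, so the two cannot be told apart on these data.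

Compound 3, `COc1ccc(/C=C2\CCC/C(=C\c3cc(Cl)cc(Cl)c3)C2=O)cc1OC`, has not yet been measured in this assay. Compared with compound 2 it carries 3,5-dichlorophenyl in place of 2-bromophenyl on a double-bonded chain carbon bound to a double-bonded ring carbon. Among the measured compounds shown here, no step between two measured compounds isolates this kind of change, so there is no direct precedent for it here. The two measured compounds, which differ in several places at once, nonetheless land close together, and the replacement of one halogenated phenyl group by another is expected to leave the number near that of compound 2. The step from compound 2 to compound 3 is therefore estimated at a 1.2-fold lower number from compound 2 to compound 3 (0.08 log units; within the scatter), that is, no change beyond the scatter. For compound 3 the expected value in this assay is 18000 nM, with a range from 8000 nM to 40000 nM.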

Compound 3, half-maximal inhibitory concentration: 8300 nM
The estimate for compound 3 lay 2.2-fold (0.34 log units) above the measured number; low and high end bracket the measured number.
By their numbers in this assay, from the lowest: compounds 3, 1 and 2 (each within the scatter of the next, the first and the last beyond it).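

In this assay, 3,5-dichlorophenyl in place of 2-bromophenyl on a double-bonded chain carbon bound to a double-bonded ring carbon gives a 2.6-fold lower number from compound 2 to compound 3 (0.42 log units; beyond the scatter), and this is the first step shown that changes one place alone. The step is modest, but it lies beyond the scatter, so this place is not indifferent to which halogenated phenyl group it carries, something the two earlier compounds could not show while they differed in several places at once. Nothing at hand explains the step.

The change alters the kind of halogen, the number of halogen atoms and where they sit all in one step, so the compounds shown do not separate these, and a monochlorophenyl or a dibromophenyl group at the same place would be needed to tell them apart. They also leave open whether the halogens are needed at all, which a plain phenyl group or a phenyl group bearing an amine or a carboxylic acid would test in this assay.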